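The compounds below may be only part of what the source reports. "The series", "measured", "known", "first", "only" and "open" are said of these compounds alone.

Measured to date:
compound 1, `Cn1c(-c2ccccc2C(F)(F)F)nnc1C12CCC(CCCC(C)(F)F)(CC1)CC2`: 94%
compound 2, `CC(C)S(=O)(=O)CCC12CCC(c3nnc(-c4ccccc4C(F)(F)F)n3C)(CC1)CC2`: 59%
compound 3, `Cn1c(-c2ccccc2C(F)(F)F)nnc1C12CCC(COc3ccc(S(C)(=O)=O)cc3)(CC1)CC2`: 28%

All three share one core and were read in a functional assay on the whole organism (strain ICR) for inhibition, with Mus musculus as the target, with a stated time of 16 h, at a dose of 10 mg/kg by the oral route; a lower number here means less inhibition, a higher number more inhibition at the dose given (going by the name of the read-out). Compound 3 stands lowest of the three numbers; compound 2 is its nearest neighbour and compound 1 the furthest, both gaps beyond the scatter: a number 31 percentage points lower from compound 2 to compound 3 (beyond the scatter) and a number 66 percentage points lower from compound 1 to compound 3 (beyond the scatter). The two chain variants are themselves separated by a number 35 percentage points lower from compound 1 to compound 2 (beyond the scatter).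

Compound 4, `CCS(=O)(=O)CCCCC12CCC(c3nnc(-c4ccccc4C(F)(F)F)n3C)(CC1)CC2`, is not yet measured. Against compound 3 the change is 3-(ethylsulfonyl)propyl in place of 4-(methylsulfonyl)phenoxy on a saturated chain carbon bound to a saturated ring carbon. The step bearing most directly on it is a number 31 percentage points lower from compound 2 to compound 3 (beyond the scatter), where (isopropylsulfonyl)methyl gave way to 4-(methylsulfonyl)phenoxy; compound 4 returns to a sulfonyl-bearing chain of that kind, so that step is taken as a template in reverse. The larger step of a number 66 percentage points lower from compound 1 to compound 3 (beyond the scatter) marks the most any chain has given so far in this series, but that chain carried no sulfonyl group. A step upward beyond the scatter is therefore expected, a number 30 percentage points higher from compound 3 to compound 4 (beyond the scatter), landing near compound 2 rather than compound 1. For compound 4 the estimated value is 58%, with a range from 35% to 80%.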

Compound 4, a percentage reported as inhibition, in the whole organism at one dose (the size of the read-out at that dose, not a potency): 58%
The estimate for compound 4 equals the measured number at the digits printed; measured number inside the range.
By their numbers in this assay, from the lowest: compound 3; then compounds 4 and 2 (each within the scatter of the next); then compound 1.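

In this assay the two alkyl sulfonyl chains read alike, with a number 1 percentage points lower from compound 2 to compound 4 (within the scatter) for 2-(ethylsulfonyl)ethyl in place of isopropylsulfonyl, so this change separates nothing at this position. The step of a number 30 percentage points higher from compound 3 to compound 4 (beyond the scatter) shows that a sulfonyl group alone does not fix the number: with 3-(ethylsulfonyl)propyl in place of 4-(methylsulfonyl)phenoxy, two sulfonyl-bearing compounds now lie apart beyond the scatter, while a number 36 percentage points lower from compound 1 to compound 4 (beyond the scatter) shows that compound 4 stays well short of the difluorinated chain of compound 1. No supporting measurement bears on these steps.

Still open, on these data alone, is whether a chain ending in a sulfonamide, a carboxylic acid or an amine would read near compound 4 or near compound 1, and whether a longer chain carrying the terminal difluoro group would hold the number of compound 1. As far as these compounds go, all four compounds share one core and one dose, so whether these steps carry over to another core or another dose also remains open.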